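The source may report more compounds than this note shows. Statements on the series, on what has been measured and on what is new or still open speak of the compounds shown alone.

Working notes on the series. Among the compounds with values here, in a functional assay (aorta) with Rattus norvegicus as the target (a higher number here means that more compound is needed for the effect, a lower number that less compound is needed), compound 3 `CCCNC1=NS(=O)(=O)c2cc(Cl)ccc2N1` gives 55.5 uM, the lowest number of the three measured so far. Compound 2 `CNC1=NS(=O)(=O)c2cc(Cl)ccc2N1` gives 142 uM and compound 1 `CCCNC1=NS(=O)(=O)c2cc(F)ccc2N1` gives 166 uM.

Compound 4 `CCC(C)(C)NC1=NS(=O)(=O)c2cc(Cl)ccc2N1` keeps the chloro of compound 3 and carries 1,1-dimethylpropyl in place of propyl on an amine nitrogen.

Within the data shown here, the closest precedent is the change at this same amine nitrogen, a 2.6-fold lower number from compound 2 to compound 3 (0.41 log units; beyond the scatter), a modest step beyond the scatter. The halogen change, a 3.0-fold lower number from compound 1 to compound 3 (0.48 log units; beyond the scatter), is of similar size but lies elsewhere on the molecule and gives no guide here. Among the measured compounds shown here, the single step at the amine nitrogen suggests a further modest move to a lower number in this assay, although no chain of the 1,1-dimethylpropyl kind has been measured and the direction remains uncertain.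

The expected step is a 2.2-fold lower number from compound 3 to compound 4 (0.35 log units; beyond the scatter). Compound 4 is estimated at 25 uM, with an expected range from 8 uM to 80 uM.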

Compound 4, concentration for half-maximal effect: 0.29 uM
Estimate against measurement, compound 4: 86-fold (1.94 log units) above; the measured number lies below the stated range.
By their numbers in this assay, from the lowest: compound 4; then compound 3; then compounds 2 and 1 (each within the scatter of the next).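

In this assay, the group on this amine nitrogen proves far more consequential than the change from methyl to propyl indicated (a 2.6-fold lower number from compound 2 to compound 3 (0.41 log units; beyond the scatter)). Replacing propyl with 1,1-dimethylpropyl gives a much larger step (a 190-fold lower number from compound 3 to compound 4 (2.28 log units; beyond the scatter)), and the overall change from methyl to 1,1-dimethylpropyl is larger still (a 490-fold lower number from compound 2 to compound 4 (2.69 log units; beyond the scatter)). No data given here explain the size of this step.

The compounds shown do not separate the effect of branching from that of chain length, so tert-butyl and unbranched pentyl would be the informative comparisons on this nitrogen. As far as these compounds go, it also remains open whether 1,1-dimethylpropyl gives a step of similar size with fluoro in place of chloro on the aromatic carbon.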